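The source may hold more compounds than are shown below. What is called first, only, known or untested is meant among the compounds shown, and "the series" means these compounds.

Compound 1 `CCOC(=O)N1CCN(CCCOc2ccc(-c3c[nH]cn3)cc2)CC1` gives 69200 nM in an assay on isolated protein for binding affinity to histamine H2 receptor (Homo sapiens); a lower number here means a stronger inhibitor, a higher number a weaker inhibitor.
Compound 2 `CCOC(=O)N1CCN(CCCOc2ccc(-c3cccs3)cc2)CC1` gives 33100 nM in this assay.
Compound 3 `N#Cc1ccc(-c2ccc(OCCCN3CCCNCC3)cc2)cc1` gives 7760 nM in this assay.

Among these three, compound 3 stands at the lowest number, that is, the strongest binding seen so far. Going by the values given here, the only step between measured compounds that differ in one place is a 2.1-fold lower number from compound 1 to compound 2 (0.32 log units; beyond the scatter), and it concerns the group at the far end of the molecule, not the ring at the end of the chain.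

Compound 4 `CC1CCCN(CCCOc2ccc(-c3ccc(C#N)cc3)cc2)C1` is the next to be measured in this assay. It differs from compound 3 in one place: 3-methylpiperidin-1-yl in place of 1,4-diazepan-1-yl on a saturated chain carbon, three bonds along the chain from an oxygen on an aromatic ring. Among the compounds with values here, no measured step bears on a change of this kind, since compounds 1 and 2 share the same ring at that end of the chain and differ elsewhere. Within the data shown here, the only guide is that the chain-end ring of compound 3 was present in the compound with the lowest number. With nothing else to go on, the step from compound 3 to compound 4 is expected to be a 1.5-fold higher number from compound 3 to compound 4 (0.19 log units; within the scatter), small and uncertain in direction. Compound 4 is therefore estimated at 12000 nM, within a range from 2500 nM to 60000 nM.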

Compound 4, inhibition constant: 11700 nM
Compound 4: middle estimate off by 1.0-fold (0.01 log units), on the high side; the range from low to high includes it.
By their numbers in this assay, from the lowest: compounds 3 and 4 (each within the scatter of the next); then compound 2; then compound 1.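

In this assay, going by these compounds alone, the change of 3-methylpiperidin-1-yl in place of 1,4-diazepan-1-yl gives a 1.5-fold higher number from compound 3 to compound 4 (0.18 log units; within the scatter), so this pair offers the first direct reading at this position, and the two compounds cannot be told apart. The swap is not a small one on paper: a seven-membered ring with 2 hetero atoms and 1 hydrogen-bond donor gives way to a six-membered ring with 1 hetero atom and 0 hydrogen-bond donors, yet the heavy-atom count stays the same and the binding stays within the scatter, which means that in this pair the second ring nitrogen and its hydrogen are not needed to keep this level of binding. Nothing available explains why the two groups read alike.

Because the new group differs from the old one in ring size, ring nitrogen and methyl all at once, this single pair cannot separate those three changes, and plain piperidin-1-yl or morpholin-4-yl at the same place would be needed to do so. Going by these compounds, whether a longer chain would alter binding also stays open, and the steps from compounds 1 and 2 to compounds 3 and 4 cannot be read, since these differ in more than one place.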